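Swapping a nitrile for an amide at the chain end

This account rests on a few compounds, and the source may have more. Where it says the series, first, only, none or still open, it means among the compounds named here.

Compound 1: `CCCc1c[nH]c2ccc(F)cc12`; in an assay on isolated protein (urine) for inhibition of Myeloperoxidase (Homo sapiens), with a stated time of 5 min (on this read-out higher numbers stand for weaker inhibition and lower numbers for stronger inhibition), compound 1 gives only a limit, > 100 nM.
Compound 2: `N#CCCCc1c[nH]c2ccc(F)cc12`; compound 2 gives 63 nM.

Compound 2 thus holds the only number shown; the other value is a limit (the limit of > 100 nM in this assay, at which 1 of the 2 values shown sits). Among the compounds with values here, the single measured step, an at least 1.5-fold lower number from compound 1 to compound 2 (0.20 log units; that floor lies within the scatter), brought in the cyano that compound 3, `NC(=O)CCCCc1c[nH]c2ccc(F)cc12`, now gives up: carbamoylmethyl in place of cyano on a saturated chain carbon, three bonds along the chain from an aromatic carbon. That step barely cleared its floor, so it offers no firm direction. Compound 3 is therefore expected to sit close to compound 2, a step of a 1.3-fold higher number from compound 2 to compound 3 (0.10 log units; within the scatter), estimated at 80 nM, within 25 nM to 250 nM.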

Compound 3, half-maximal inhibitory concentration: 39 nM
For compound 3 the middle estimate is 2.1-fold (0.31 log units) above the measured one, and the stated range covers the measured number.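

In this assay, putting carbamoylmethyl in place of cyano gives a 1.6-fold lower number from compound 2 to compound 3 (0.21 log units; within the scatter), so these two chain ends cannot be told apart at this position. Set against the unsubstituted chain, the same carbamoylmethyl gives an at least 2.5-fold lower number from compound 1 to compound 3 (0.40 log units; beyond the scatter), the first step at this position that clears the scatter. That size is only a floor, and the true gap remains unknown: the limit of > 100 nM in this assay, at which 1 of the 3 values shown sits.

From the compounds shown here alone, whether a carboxylic acid or an amine at the chain end would hold this level stays open. So does the effect of a longer chain.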